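Chloro removal on the fused ring: cytotoxicity notes

The source may report more compounds than this note shows. Statements on the series, on what has been measured and on what is new or still open speak of the compounds shown alone.

Measured so far:
compound 1 `CCN(CC)CN1C(=O)/C(=N/NC(N)=S)c2cc(Cl)ccc21` 100000 nM
compound 2 `CCN(CC)CN1C(=O)/C(=N/NC(=S)Nc2ccc(Cl)cc2)c2cc(Cl)ccc21` >= 800 nM

For the measured compounds named here, compound 1 holds the only true number in an ADME assay on MDCK cells (Canis lupus familiaris) for cytotoxicity; on this read-out lower numbers stand for higher toxicity in this test and higher numbers for lower toxicity in this test; the second value shown is a limit. For compound 2 this assay reports only the limit >= 800 nM, shown as the limit of >= 800 nM in this assay, at which 1 of the 2 values shown sits. Going by the values given here, the step that the limit leaves unreadable from compound 1 to compound 2 is therefore unreadable, and no measured step speaks to the change now at hand.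

Compound 3 `CCN(CC)CN1C(=O)/C(=N/NC(N)=S)c2ccccc21` differs from compound 1 by hydrogen in place of chloro on an aromatic carbon. With nothing bearing on it, no step beyond the scatter is expected: the estimate is no change at the digits printed from compound 1 to compound 3 (within the scatter). Compound 3 is thus expected at 100000 nM, within 30000 nM to 200000 nM.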

Compound 3, minimum cytotoxic concentration: 100000 nM
Compound 3: the middle estimate sits on the measured number at the digits printed, and the stated range covers the measured number.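

In this assay, for the compounds shown here, hydrogen in place of chloro on this aromatic carbon gives no change at the digits printed from compound 1 to compound 3 (within the scatter) and so, for the first time, a readable step at this position of the shared core. With the terminal thiourea nitrogen unsubstituted, the chlorine is thus not needed to hold this read-out. No measured property on hand accounts for this outcome.

Going by these compounds, whether an amine or a methoxy group on the same carbon would leave the read-out unmoved stays open. On these data alone, the value of compound 2 is a limit, so its step cannot be read, and the effect of chloro removal alongside the 4-chlorophenyl also stays open.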